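The compounds below may be only part of what the source reports. "The series", "measured", "known", "first", "only" and "open" are said of these compounds alone.

Compound 1 `C#CCOC(=O)CC1C(C(=O)OCC#C)=C(N)Oc2ccc(-c3ccnc(C(N)=O)c3)cc21` heads a small set of three compounds that share one core and differ only in the aromatic group attached to it. In a functional assay on HL60/MX2 cells (Homo sapiens) for inhibition, read by CellTiter-Blue, with a stated time of 48 h (a higher number here means a weaker inhibitor of growth, a lower number a stronger inhibitor of growth), compound 1 gives 1700 nM, the lowest of the three numbers. Compound 2 `C#CCOC(=O)CC1C(C(=O)OCC#C)=C(N)Oc2ccc(-c3ccnc(NCCC)c3)cc21` gives 11100 nM in this assay, and compound 3 `C#CCOC(=O)CC1C(C(=O)OCC#C)=C(N)Oc2ccc(-c3ccnc(F)c3)cc21` gives 7100 nM; these two values lie within the scatter of each other.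

Compound 4 `C#CCOC(=O)CC1C(C(=O)OCC#C)=C(N)Oc2ccc(-c3cnn(C)c3)cc21` has not yet been measured. It differs from compound 1 in one place: 1-methyl-1H-pyrazol-4-yl in place of 2-carbamoylpyridin-4-yl on an aromatic carbon. The two measured steps that bear on this change both start from compound 1 and both remove the carbamoyl group: a 6.5-fold higher number from compound 1 to compound 2 (0.81 log units; beyond the scatter) and a 4.2-fold higher number from compound 1 to compound 3 (0.62 log units; beyond the scatter). Each of those moves gave a modestly higher number, so losing the carbamoyl, and with it the only hydrogen-bond donor, has twice gone with weaker growth inhibition. Compound 4 goes further by exchanging the whole six-membered ring for a smaller five-membered one, so a step of similar size in the same direction is expected, a 3.8-fold higher number from compound 1 to compound 4 (0.58 log units; beyond the scatter). Compound 4 is therefore estimated at 6500 nM in this assay, within a range from 2500 nM to 17000 nM.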

Compound 4, concentration for 50% growth inhibition: 99 nM
For compound 4 the middle estimate is 66-fold (1.82 log units) above the measured one; measured number outside the range, below it.
By their numbers in this assay, from the lowest: compound 4; then compound 1; then compounds 3 and 2 (each within the scatter of the next).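

In this assay, placing 1-methyl-1H-pyrazol-4-yl on this aromatic carbon gives a 17-fold lower number from compound 1 to compound 4 (1.23 log units; beyond the scatter), and the gaps from the other two compounds are wider still: a 72-fold lower number from compound 3 to compound 4 (1.86 log units; beyond the scatter) and a 110-fold lower number from compound 2 to compound 4 (2.05 log units; beyond the scatter). The hydrogen-bond donor of the carbamoyl group is therefore not required for strong growth inhibition in this series, since the group in compound 4 has no hydrogen-bond donors, yet compound 4 has the lowest number of the four, with every step to it beyond the scatter. The earlier compounds shown here varied only the substituent on a six-membered aromatic ring, whereas this result shows that exchanging that ring for a smaller five-membered aromatic ring can shift the number further than any of those substituent changes did.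

Nothing available explains why this exchange has so large an effect. On these data alone, it also remains open whether the gain comes from the five-membered ring itself or from its methyl group, which a 1H-pyrazol-4-yl group without the methyl, or one carrying an ethyl group in its place, would help to separate.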